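The source may hold more compounds than are shown below. What is called first, only, known or untested is meant among the compounds shown, and "the series" means these compounds.

Measured compounds:
compound 1, `CC1=CC[C@H](C(C)(C)NC(=S)N/N=C/c2ccccc2)CC1`: 6300 nM
compound 2, `CC1=CC[C@H](C(C)(C)NC(=S)N/N=C/c2ccc(F)cc2)CC1`: > 100000 nM

In a functional assay on K562 cells (Homo sapiens) for inhibition, read by sulforhodamine B assay, with a stated time of 48 h (a higher number here means a weaker inhibitor of growth, a lower number a stronger inhibitor of growth), compound 1 gives 6300 nM. For compound 2 the reported value > 100000 nM is a limit of the assay and not a number (the limit of > 100000 nM in this assay, at which 1 of the 2 values shown sits); compound 2 therefore stands at the weak end of everything shown, with no bounded value of its own. For the measured compounds named here, the single measured step, an at least 15-fold higher number from compound 1 to compound 2 (1.20 log units; beyond the scatter), is large and beyond the scatter. Compound 3, `CC1=CC[C@H](C(C)(C)NC(=S)N/N=C/c2ccccc2Cl)CC1`, differs from compound 2 by 2-chlorophenyl in place of 4-fluorophenyl on a carbon with a double bond to nitrogen. The step from compound 1 to compound 2 bears on this only loosely: it shows that a halogen on the aromatic ring weakened growth inhibition, and compound 3 also carries a halogen there, so weak inhibition is expected, though the size of the step cannot be read from a limit. Compound 3 is expected near 50000 nM, between 8000 nM and 200000 nM. The expected step is an at least 2.0-fold lower number from compound 2 to compound 3 (0.30 log units; that floor lies within the scatter), with a fair chance that only a limit is reported.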

Compound 3, concentration for 50% growth inhibition: 5600 nM
Beside the measured number, compound 3's estimate is 8.9-fold (0.95 log units) above it, and the stated range ends above it.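

In this assay, a halogen on the aromatic ring does not in itself cost growth inhibition: chloro in place of hydrogen gives a 1.1-fold lower number from compound 1 to compound 3 (0.05 log units; within the scatter), so the 2-chlorophenyl and unsubstituted compounds cannot be told apart. Placing 2-chlorophenyl in place of 4-fluorophenyl on a carbon with a double bond to nitrogen gives an at least 17-fold lower number from compound 2 to compound 3 (1.25 log units; beyond the scatter), so the weakness of compound 2 does not extend to every halogen-bearing phenyl group here. The value of compound 2 is a limit of the assay and not a number: the limit of > 100000 nM in this assay, at which 1 of the 3 values shown sits.

This change alters both the halogen and its ring position, so the compounds shown do not separate the two; a 4-chlorophenyl or 2-fluorophenyl group would. As far as these compounds go, how a methoxy group or an amine on the ring would read remains open.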